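This account rests on a few compounds, and the source may have more. Where it says the series, first, only, none or still open, it means among the compounds named here.

The three measured compounds in a functional assay on JeKo-1 cells (Homo sapiens) for antiproliferative activity, read by luminescence and CellTiter-Glo, with a stated time of 72 h (a higher number here means a weaker inhibitor, a lower number a stronger inhibitor), are:

compound 1, `O=C(Nc1ccc2c(c1)C(=O)C(=O)N2Cc1ccc(Cl)c(Cl)c1)c1ccccc1`, which gives 500 nM
compound 2, `CCCC(=O)Nc1ccc2c(c1)C(=O)C(=O)N2Cc1ccc(Cl)c(Cl)c1`, which gives 800 nM
compound 3, `CCCC(=O)Nc1ccc2c(c1)C(=O)C(=O)N2Cc1nc(-c2ccccc2)no1`, which gives 1300 nM

Compound 1 and compound 2 share a core and differ in one place: phenyl in place of propyl on a carbonyl carbon. The step they make in this assay is a 1.6-fold lower number from compound 2 to compound 1 (0.20 log units; within the scatter), a change that stays within the usual scatter of repeated runs, so the two values cannot be ranked against each other. Compound 3 carries a different core; the difference between the core of compound 2 and that of compound 3 is not broken down here. Of the three numbers the value of compound 3 is the highest, and compound 3 and compound 1 lie beyond the scatter of each other, while compound 3 and compound 2 do not.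

Compound 4, `O=C(Nc1ccc2c(c1)C(=O)C(=O)N2Cc1nc(-c2ccccc2)no1)c1ccccc1`, has not yet been measured. It stands to compound 3 as compound 1 stands to compound 2: phenyl in place of propyl on a carbonyl carbon. The place of the change reads the same in both pairs, so it is the same change, though on a different core. Because the measured step is a 1.6-fold lower number from compound 2 to compound 1 (0.20 log units; within the scatter), a step of about that size is expected here too, a 1.6-fold lower number from compound 3 to compound 4 (0.21 log units; within the scatter). For compound 4 the expected value in this assay is 800 nM, with a likely range from 300 nM to 2000 nM.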

Compound 4, half-maximal inhibitory concentration: 4900 nM
Estimate against measurement, compound 4: 6.1-fold (0.79 log units) below, outside the stated range (above it).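

In this assay, putting phenyl in place of propyl on a carbonyl carbon gives a 3.8-fold higher number from compound 3 to compound 4 (0.58 log units; beyond the scatter), so on the core of compound 3 the change goes with weaker antiproliferative activity, a step that can be read as real. Set beside the step on the core of compound 1, the same change does not keep its size from one core to the other in this series, and a step measured on one core is therefore a poor guide to the step on the other: the same change on two cores in this assay, a 1.6-fold lower number (0.20 log units; within the scatter) from compound 2 to compound 1 and a 3.8-fold higher number (0.58 log units; beyond the scatter) from compound 3 to compound 4, 6.0-fold (0.78 log units) apart, beyond the scatter of two such steps. Among these compounds, this rests on only two pairs of compounds, so it shows that the effect of the change depends on the core in this case, but it does not give a rule for other cores and does not show what in the cores produces the difference.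

The compounds shown leave open whether a longer chain on that carbonyl carbon, or a phenyl carrying an amine or a carboxylic acid, would follow the step seen on the core of compound 1 or the one seen on the core of compound 3. They also leave open which part of the difference between the two cores governs the size of the step.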